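This account rests on a few compounds, and the source may have more. Where it says the series, first, only, none or still open, it means among the compounds named here.

Compounds measured so far:

compound 1, `CC(C)N(CCN(C(=O)Nc1cccc([N+](=O)[O-])c1)C1CC[C@]2(c3cccc(C#N)c3)CC2C1)C(C)C` — 2.7 nM
compound 2, `CC(C)N(CCN(C(=O)Nc1cccc(Br)c1)C1CC[C@]2(c3cccc(C#N)c3)CC2C1)C(C)C` — 5.7 nM
compound 3, `CC(C)N(CCN(C(=O)Nc1cccc(F)c1)C1CC[C@]2(c3cccc(C#N)c3)CC2C1)C(C)C` — not yet measured

Among the compounds with values here, in a functional assay for antagonist activity at melanin-concentrating hormone receptor 1 (Homo sapiens) (on this read-out lower numbers stand for stronger inhibition and higher numbers for weaker inhibition), compound 2 gives 5.7 nM, the highest of the two numbers so far; its nearest neighbour is compound 1, which in this assay gives 2.7 nM. Within the data shown here, the one step measured so far, a 2.1-fold higher number from compound 1 to compound 2 (0.32 log units; beyond the scatter), is modest and concerns a substituent exchange at the same aromatic carbon.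

Compound 3 differs from compound 2 by fluoro in place of bromo on an aromatic carbon. Among the measured compounds shown here, no measured step swaps one halogen for another, so the size of this change cannot be read directly from the data; the only step that bears on it, a 2.1-fold higher number from compound 1 to compound 2 (0.32 log units; beyond the scatter), suggests that changes at this position are modest. In this assay a small step, expected to be at or near the scatter, is estimated: a 1.2-fold higher number from compound 2 to compound 3 (0.09 log units; within the scatter). Compound 3 is therefore estimated at 7 nM, with a range from 2.5 nM to 20 nM.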

Compound 3, inhibition constant: 2.1 nM
The estimate for compound 3 lay 3.3-fold (0.52 log units) above the measured number, outside the stated range (below it).
By their numbers in this assay, from the lowest: compounds 3 and 1 (each within the scatter of the next); then compound 2.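

In this assay, replacing one halogen with another on this aromatic carbon proves to be a step beyond the scatter, with 3-bromophenyl giving way to 3-fluorophenyl (a 2.7-fold lower number from compound 2 to compound 3 (0.43 log units; beyond the scatter)). Fluoro and nitro cannot be separated at this carbon (a 1.3-fold lower number from compound 1 to compound 3 (0.11 log units; within the scatter)), so compound 2, with bromo, now stands alone with the highest number of the three, whereas the earlier pair alone could not show whether nitro or bromo was the exception. Nothing available accounts for this difference between bromo and fluoro.

The compounds shown leave open where chloro, the halogen between fluoro and bromo in size of atom, would fall on this carbon, and whether an unsubstituted phenyl would match compound 3. They also leave open how a methoxy group, an amine or a carboxylic acid would read there.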